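A Second Ring Nitrogen in the Amide Substituent

The source may report more compounds than this note shows. Statements on the series, on what has been measured and on what is new or still open speak of the compounds shown alone.

Three compounds share one core and differ only in the group on the amide nitrogen. In a physicochemical assay for lipophilicity, read by HPLC, in phosphate buffer, measured as chromatographic lipophilicity, at pH 7.4 (on this read-out lower numbers stand for lower lipophilicity and higher numbers for higher lipophilicity), compound 1 `COc1ccc2nc(C)cc(OCC(=O)Nc3cccc(C)c3)c2c1` gives 4.83, compound 2 `COc1ccc2nc(C)cc(OCC(=O)Nc3c(C)cccc3C)c2c1` gives 4.55, and compound 3 `COc1ccc2nc(C)cc(OCC(=O)Nc3ccccn3)c2c1` gives 3.49, the lowest of the three, with compound 2 nearest and compound 1 furthest. Compound 4 `COc1ccc2nc(C)cc(OCC(=O)Nc3ccncn3)c2c1` carries the change (pyrimidin-4-yl in place of pyridin-2-yl on an amide-type nitrogen). For the measured compounds named here, the steps that bear on it are a number 1.34 log units lower from compound 1 to compound 3 (beyond the scatter) and a number 1.06 log units lower from compound 2 to compound 3 (beyond the scatter), both large drops when a ring nitrogen entered the group on the amide nitrogen. A further ring nitrogen is therefore expected to lower the number again in this assay, by about a number 0.69 log units lower from compound 3 to compound 4 (beyond the scatter). For compound 4 the estimate is 2.8, with a range of 2.2 to 3.4.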

Compound 4, distribution coefficient: 2.53
For compound 4 the middle estimate is 0.27 log units above the measured one; the range from low to high includes it.
By their numbers in this assay, from the lowest: compound 4; then compound 3; then compounds 2 and 1 (each within the scatter of the next).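

In this assay the fall continues with a second ring nitrogen: pyrimidin-4-yl in place of pyridin-2-yl gives a number 0.96 log units lower from compound 3 to compound 4 (beyond the scatter) on the amide-type nitrogen, so the drop seen with the first ring nitrogen is not a single event. Against the two methyl-bearing phenyl groups, the total comes to a number 2.02 log units lower from compound 2 to compound 4 (beyond the scatter) and a number 2.30 log units lower from compound 1 to compound 4 (beyond the scatter) for the same core. No measurement here explains why the number falls with each ring nitrogen. Still open, going by these compounds, is whether a pyrazin-2-yl group would give a number close to that of the pyrimidin-4-yl group. Also open, on these data alone, is how an amine on the pyrimidin-4-yl ring would shift the number.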